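The source may hold more compounds than are shown below. What is called first, only, known or untested is meant among the compounds shown, and "the series" means these compounds.

Of the compounds shown here, two have so far been measured in a functional assay on SK-MEL-5 cells (Homo sapiens) for inhibition, read by sulforhodamine B assay, with a stated time of 48 h; on this read-out higher numbers stand for weaker inhibition of growth and lower numbers for stronger inhibition of growth. Compound 1 `O=C(Nc1cccc(-n2cc(-c3ccncc3)c(-c3ccc(Cl)c(O)c3)n2)c1)Nc1cccc(C(F)(F)F)c1` gives 1300 nM. Compound 2 `COc1cc(-c2nn(-c3cccc(NC(=O)c4cccc(C(F)(F)F)c4)c3)cc2-c2ccncc2)ccc1Cl` gives 978 nM, a number that lies within the usual scatter of that of compound 1, so the two cannot be told apart on this read-out. Compound 3 `COc1cc(-c2nn(-c3cccc(NC(=O)Nc4cccc(C(F)(F)F)c4)c3)cc2-c2ccncc2)ccc1Cl` has not yet been measured; it differs from compound 2 in one place: (3-(trifluoromethyl)phenyl)amino in place of 3-(trifluoromethyl)phenyl on a carbonyl carbon. Going by the values given here, no measured pair shows what this change does here, so only a small shift is expected, a 1.0-fold higher number from compound 2 to compound 3 (0.01 log units; within the scatter), with no set direction beyond the scatter. Compound 3 is accordingly expected to give about 1000 nM, somewhere between 400 nM and 2500 nM.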

Compound 3, concentration for 50% growth inhibition: 720 nM
Compound 3: middle estimate off by 1.4-fold (0.14 log units), on the high side; measured number inside the range.
By their numbers in this assay, from the lowest: compounds 3, 2 and 1 (each within the scatter of the next).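

In this assay, placing (3-(trifluoromethyl)phenyl)amino in place of 3-(trifluoromethyl)phenyl on a carbonyl carbon gives a 1.4-fold lower number from compound 2 to compound 3 (0.13 log units; within the scatter) and stays within the scatter, so adding this hydrogen-bond donor does not measurably alter growth inhibition here. Methyl in place of hydrogen on an oxygen on an aromatic ring gives a 1.8-fold lower number from compound 1 to compound 3 (0.26 log units; within the scatter) and also stays within the scatter, so that oxygen can carry either without a readable difference. No supporting measurement explains either result. Open, as far as these compounds go, is whether a longer chain on that oxygen, or a simple amine on the carbonyl carbon, would shift growth inhibition beyond the scatter.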